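The source may hold more compounds than are shown below. What is called first, only, known or untested is meant among the compounds shown, and "the series" means these compounds.

Three related compounds have so far been measured in an ADME assay on Vero cells (Chlorocebus sabaeus) for cytotoxicity, read by MTT assay, with a stated time of 72 h; on this read-out higher numbers stand for weaker inhibition and lower numbers for stronger inhibition. Compound 1 `S=C=NCCCCSCc1ccccc1` gives 25000 nM, compound 2 `CC[S+]([O-])CCCCN=C=S` gives 7900 nM, and compound 3 `CCC[S+]([O-])CCCCN=C=S` gives 5640 nM. Compound 3 therefore cannot be told apart from compound 2, since their numbers lie within the normal scatter of repeated measurements. Compound 1 shows a clearly higher number than compound 3.

The next compound, compound 4 `CCCC[S+]([O-])CCCCN=C=S`, extends the chain on the sulfur by one more carbon: methyl in place of hydrogen on a saturated chain carbon, three bonds along the chain from a sulfur. In words, this is methyl in place of hydrogen on a saturated chain carbon, three bonds along the chain from a sulfur, taking propyl to butyl.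

Within the data shown here, only one measured step bears on this change. The same kind of addition, made two bonds along the chain from a sulfur, gave a 1.4-fold lower number from compound 2 to compound 3 (0.15 log units; within the scatter). Compound 1 differs from the others in more than one place, so it offers no direct guide. A single step of this size cannot establish a trend, so no shift beyond the scatter is expected in this assay, at most a slight continued drift downward. The expected change is a 1.3-fold lower number from compound 3 to compound 4 (0.10 log units; within the scatter). For compound 4 the estimated value is 4500 nM, with an expected range of 2200 nM to 9000 nM.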

Compound 4, half-maximal inhibitory concentration: 5150 nM
Compound 4: the middle estimate sits 1.1-fold (0.06 log units) below what was measured; the range from low to high includes it.
By their numbers in this assay, from the lowest: compounds 4, 3 and 2 (each within the scatter of the next); then compound 1.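

In this assay, taking propyl to butyl gives a 1.1-fold lower number from compound 3 to compound 4 (0.04 log units; within the scatter), so methyl in place of hydrogen at this carbon, three bonds along the chain from a sulfur, leaves no change that can be told from repeat-measurement noise. Among these compounds, the earlier compounds offered only one such step, but the two additions taken together from ethyl to butyl give a 1.5-fold lower number from compound 2 to compound 4 (0.19 log units; within the scatter), so across ethyl, propyl and butyl this read-out shows no separable effect of chain length, even over the wider span. No measurement given here explains why these chains behave alike in this cytotoxicity read-out.

The compounds shown leave open whether a longer chain on the sulfur, such as hexyl or octyl, or a chain ending in an amine or a carboxylic acid, would move the number beyond the scatter. Also open, going by these compounds, is what sets compound 1 apart at 25000 nM, since it differs from the other compounds in more than one place and no single change can be credited with its number.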